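The compounds below may be only part of what the source reports. "The series", "measured", "known", "first", "only" and "open" are said of these compounds alone.

Measured in a functional assay on A549 cells (Homo sapiens) for antiproliferative activity, read by MTT assay, with a stated time of 48 h; a higher number here means a weaker inhibitor, a lower number a stronger inhibitor:
Compound 1, `CCc1ccccc1-n1nncc1CN1C(=O)C2(C(C#N)=C(N)Oc3c(N)cc4nc5ccccc5nc4c32)c2ccccc21`, gives 24600 nM.
Compound 2, `COc1ccccc1-n1nncc1CN1C(=O)C2(C(C#N)=C(N)Oc3c(N)cc4nc5ccccc5nc4c32)c2ccccc21`, gives 37500 nM.

Compound 2 has the highest of the two numbers in this assay, and its nearest neighbour is compound 1, which sits within the usual scatter of it, so the two are not distinguishable on these data. The change from compound 1 to compound 2, a methoxy in place of ethyl on an aromatic carbon, gave a 1.5-fold higher number from compound 1 to compound 2 (0.18 log units; within the scatter).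

Compound 3, `N#CC1=C(N)Oc2c(N)cc3nc4ccccc4nc3c2C12C(=O)N(Cc1cnnn1-c1ccc([N+](=O)[O-])cc1)c1ccccc12`, differs from compound 2 as follows: 4-nitrophenyl in place of 2-methoxyphenyl on an aromatic nitrogen. Within the data shown here, no measured step touches the same kind of exchange, since the one step available swaps substituents on the phenyl ring carbon rather than replacing the whole aryl group on the ring nitrogen. Among the measured compounds shown here, that single step, within the scatter, is the only guide, and it points to no direction. The number for compound 3 is therefore expected near that of compound 2, with a wide range reflecting the absence of a comparable precedent. The step expected is a 1.3-fold lower number from compound 2 to compound 3 (0.10 log units; within the scatter). Compound 3 is estimated at 30000 nM, between 9000 nM and 100000 nM.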

Compound 3, half-maximal inhibitory concentration: > 50000 nM
Compound 3 ended at the assay's limit (the forecaster's own chance of this, stated with the estimate: 15%); middle value at least 1.6-fold (0.22 log units) away from the limit.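

Among these compounds, this is the first exchange of the whole aryl group on the aromatic nitrogen of the five-membered ring, and in this assay compound 3 gives > 50000 nM, which is a limit of the assay and not a number. The exchange gives an at least 1.3-fold higher number from compound 2 to compound 3 (0.12 log units; that floor lies within the scatter) and an at least 2.0-fold higher number from compound 1 to compound 3 (0.30 log units; that floor lies within the scatter), so 4-nitrophenyl at this place brought no lower number than 2-methoxyphenyl or 2-ethylphenyl, although neither floor clears the scatter. How far compound 3 lies past that point cannot be read, and the set now reaches the end of what the assay reports: the limit of > 50000 nM in this assay, at which 1 of the 3 values shown sits.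

The compounds shown change the substituent and where it sits on the phenyl ring together, so the effect of the one cannot be told from that of the other. On these data alone, it also remains open how an unsubstituted phenyl on the aromatic nitrogen would compare, or a phenyl ring carrying an amine or a carboxylic acid, and whether any group at this place can give a number clearly lower than those of compound 1 and compound 2.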